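Swapping Fluoro for Methoxy on the Benzylamine Arm

The compounds below may be only part of what the source reports. "The series", "measured", "known", "first", "only" and "open" are said of these compounds alone.

Of the compounds shown here, two sharing one core have so far been measured in a functional assay on BT-549 cells (Homo sapiens) for inhibition, read by sulforhodamine B assay, with a stated time of 48 h; on this read-out higher numbers stand for weaker inhibition of growth and lower numbers for stronger inhibition of growth. Compound 1 `COc1ccc(CNc2nc3cc(N)cc(N)c3nc2-c2ccccc2)cc1OC` gives 32400 nM in this assay. Compound 2 `Nc1cc(N)c2nc(-c3ccccc3)c(NCc3ccc(F)cc3)nc2c1` gives 3240 nM. Among the measured compounds shown here, the one measured step between them, a 10-fold lower number from compound 1 to compound 2 (1.00 log units; beyond the scatter), corresponds to 4-fluorophenyl in place of 3,4-dimethoxyphenyl on a saturated chain carbon bound to a nitrogen on an aromatic ring. Compound 2 therefore stands at the lower of the two numbers, separated from compound 1 by a step that lies beyond the scatter.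

Compound 3 `COc1ccc(CNc2nc3cc(N)cc(N)c3nc2-c2ccccc2)cc1` awaits measurement. Relative to compound 2 the change is methoxy in place of fluoro on an aromatic carbon, para to a large group. For the measured compounds named here, only the step of a 10-fold lower number from compound 1 to compound 2 (1.00 log units; beyond the scatter) bears on this change; it replaced two methoxy groups with one fluoro and lowered the number by a margin well beyond the scatter. Since compound 3 brings back a single methoxy, the step of a 2.5-fold higher number from compound 2 to compound 3 (0.39 log units; beyond the scatter) is expected to move the number upward, recovering part of that earlier loss. Compound 3 is thus estimated at 8000 nM, with a range from 3000 nM to 25000 nM.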

Compound 3, concentration for total growth inhibition: 30900 nM
Estimate against measurement, compound 3: 3.9-fold (0.59 log units) below, outside the stated range (above it).
By their numbers in this assay, from the lowest: compound 2; then compounds 3 and 1 (each within the scatter of the next).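

In this assay, the exchange of fluoro for methoxy on this aromatic carbon, para to a large group, now stands alone as a single change, and it gives a 9.5-fold higher number from compound 2 to compound 3 (0.98 log units; beyond the scatter). The second methoxy group of compound 1 makes no difference that can be read, since removing it gives a 1.0-fold lower number from compound 1 to compound 3 (0.02 log units; within the scatter), so the earlier step, a 10-fold lower number from compound 1 to compound 2 (1.00 log units; beyond the scatter), which combined both changes, can be assigned to the group at the position para to a large group rather than to the number of methoxy groups. No measurement is available here that accounts for this difference between fluoro and methoxy.

The compounds shown leave open whether the lower number of compound 2 belongs to fluoro itself or only to the absence of methoxy, a question that a plain phenyl ring with hydrogen at this position would address. From the compounds shown here alone, whether chloro, a hydroxyl group or an amine at the same carbon would fall with compound 2 or with compound 3 also remains open.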